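The source may report more compounds than this note shows. Statements on the series, on what has been measured and on what is new or still open speak of the compounds shown alone.

Among the measured compounds shown here, in a functional assay on the whole organism (Tail, strain ICR) with Mus musculus as the target, in the tail flick test, with a stated time of 120 min, at a dose of 25 umol/kg by the oral route (a higher number here means a stronger effect of the compound at the dose given, a lower number a weaker effect), compound 1 `O=C(O)[C@@H]1CCCN1C(=O)CN(c1nc(Cl)nc2[nH]cnc12)C1CC1` gives 23.6%, the second highest of the three numbers known. Compound 3 `O=C(CN(c1nc(Cl)nc2[nH]cnc12)C1CC1)NCC(=O)OCc1ccccc1` gives 21.7%, within the scatter of compound 1. Compound 2 `O=C(OCc1ccccc1)[C@@H]1CCCN1C(=O)CN(c1nc(Cl)nc2[nH]cnc12)C1CC1` gives 38.4%; the step of a number 14.8 percentage points higher from compound 1 to compound 2 (beyond the scatter) lies beyond the scatter. Compound 4 `CC(C)[C@H](NC(=O)CN(c1nc(Cl)nc2[nH]cnc12)C1CC1)C(=O)O` differs from compound 1 by (1-carboxy-2-methylpropyl)amino in place of 2-carboxypyrrolidin-1-yl on a carbonyl carbon. For the measured compounds named here, the only measured step concerns the ester and does not touch this part of the molecule; no step reported bears on the present change, and compounds 2 and 3 show only their two values. Compound 4 is therefore expected to show a step of a number 1.6 percentage points lower from compound 1 to compound 4 (within the scatter), not beyond the scatter. Compound 4 is estimated at 22%, with a range from 8% to 38%.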

Compound 4, a percentage reported as activity, at one dose (the size of the read-out at that dose, not a potency): 17.1%
For compound 4 the middle estimate is 4.9 percentage points above the measured one; the measured number falls inside the stated range.
By their numbers in this assay, from the lowest: compounds 4, 3 and 1 (each within the scatter of the next); then compound 2.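

In this assay, (1-carboxy-2-methylpropyl)amino in place of 2-carboxypyrrolidin-1-yl on a carbonyl carbon gives a number 6.5 percentage points lower from compound 1 to compound 4 (within the scatter). At this position, then, the five-membered ring can give way to an open chain of the same heavy-atom count without a step beyond the scatter. Nothing at hand accounts for this result.

As far as these compounds go, it remains open whether a benzyl ester of compound 4 would give a step like the one from the acid to the ester in the proline-type series, a number 14.8 percentage points higher from compound 1 to compound 2 (beyond the scatter). Also open, from the compounds shown here alone, is how an amine or a longer chain would read on this carbonyl carbon.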